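Branched to straight acyl chain on a sugar acetonide ester

The source may report more compounds than this note shows. Statements on the series, on what has been measured and on what is new or still open speak of the compounds shown alone.

Three esters of a shared core have been measured in a functional assay on K562 cells (Homo sapiens) for inhibition; a lower number here means a stronger inhibitor, a higher number a weaker inhibitor. Compound 1 `CC(=O)OC1C(C(O)CO)OC2OC(C)(C)OC21` gives 3800000 nM, compound 2 `CC1(C)OC2OC(C(O)CO)C(OC(=O)C(C)(C)C)C2O1` gives 1500000 nM, and compound 3 `CC1(C)OC2OC(C(O)CO)C(OC(=O)CC(c3ccccc3)c3ccccc3)C2O1` gives 500000 nM. Compound 2 thus holds the second highest of the three numbers, placed between compound 1 and compound 3. Compound 4 `CCCCC(=O)OC1C(C(O)CO)OC2OC(C)(C)OC21` differs from compound 2 in one place: butyl in place of tert-butyl on a carbonyl carbon. Going by the values given here, the one step that bears on this site is a 2.5-fold lower number from compound 1 to compound 2 (0.40 log units; beyond the scatter), where a larger acyl group lowered the number. Here the acyl group keeps its size and only changes shape, so a step no larger than the scatter is expected, a 1.3-fold lower number from compound 2 to compound 4 (0.10 log units; within the scatter). Compound 4 is accordingly estimated at 1200000 nM, with a range from 500000 nM to 3000000 nM.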

Compound 4, half-maximal inhibitory concentration: 2000000 nM
Compound 4: the middle estimate sits 1.7-fold (0.22 log units) below what was measured; measured number inside the range.
By their numbers in this assay, from the lowest: compound 3; then compounds 2, 4 and 1 (each within the scatter of the next, the first and the last beyond it).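

In this assay, butyl in place of tert-butyl on a carbonyl carbon gives a 1.3-fold higher number from compound 2 to compound 4 (0.12 log units; within the scatter) and so shows that this change of shape in the acyl group has no effect that can be told from the scatter. Propyl in place of hydrogen on a saturated chain carbon bound to a carbonyl carbon gives a 1.9-fold lower number from compound 1 to compound 4 (0.28 log units; within the scatter), so enlarging the acetyl group does not always give a step as clear as a 2.5-fold lower number from compound 1 to compound 2 (0.40 log units; beyond the scatter). No available data explain these numbers.

Going by these compounds, whether a longer chain or an amine on this carbonyl carbon would shift the number remains open.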